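Configuration Alone Shifts Inhibition of a Cytosolic Glycosidase

The source may hold more compounds than are shown below. What is called first, only, known or untested is meant among the compounds shown, and "the series" means these compounds.

This account concerns three compounds that share one set of atoms and bonds and differ only in the configuration drawn at their ring carbons. In an assay on isolated protein for inhibition of cytosolic endo-beta-N-acetylglucosaminidase (Homo sapiens), tested at 1000 uM (on this read-out higher numbers stand for more inhibition at the one concentration tested (going by the name of the read-out) and lower numbers for less inhibition), compound 1, `O=C(O)[C@H]1NC[C@H](O)[C@H](O)[C@H]1O`, gives 7.6%. Compound 2, `O=C(O)[C@H]1NC[C@@H](O)[C@H](O)[C@@H]1O`, gives 42% in this assay, which is the highest of the two numbers measured; its nearest neighbour is compound 1, a number that lies lower beyond the scatter. Within the data shown here, the measured step of a number 34.4 percentage points higher from compound 1 to compound 2 (beyond the scatter) shows how much the configuration alone can move the read-out, and the fact that compounds 1 and 2 differ only in the configuration as drawn is the only evidence available for that step.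

Compound 3, `O=C(O)[C@@H]1NC[C@H](O)[C@H](O)[C@H]1O`, has not yet been measured. Its relation to compound 2 is the two compounds have the same atoms and bonds and differ only in configuration as drawn: 3 of 4 stereo elements differ; a stereocentre at a saturated ring carbon is drawn S in compound 2 and R in compound 3; a stereocentre at a saturated ring carbon is drawn R in compound 2 and S in compound 3; a stereocentre at a saturated ring carbon is drawn R in compound 2 and S in compound 3. Among the measured compounds shown here, the single measured step bearing on this change is the large one from compound 1 to compound 2, so a step of comparable size in either direction would not be surprising. Since more stereo elements are inverted here than in that step, compound 3 is expected to fall back toward a lower read-out, with an estimated step of a number 22 percentage points lower from compound 2 to compound 3 (beyond the scatter). Compound 3 is therefore estimated to give 20% in this assay, within the range 3% to 50%.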

Compound 3, a percentage reported as inhibition, at one concentration (the size of the read-out at that concentration, not a potency): 39%
The estimate for compound 3 lay 19 percentage points below the measured number; the measured number falls inside the stated range.
By their numbers in this assay, from the lowest: compound 1; then compounds 3 and 2 (each within the scatter of the next).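

In this assay a change at 1 of 4 stereo elements gives a number 31.4 percentage points higher from compound 1 to compound 3 (beyond the scatter) and thus shows that inverting a single stereocentre at a saturated ring carbon is enough to move the read-out by a large amount. Compounds 2 and 3 differ at 3 of 4 stereo elements, yet the result is a number 3 percentage points lower from compound 2 to compound 3 (within the scatter) so across these three compounds the count of inverted stereocentres does not follow the size of the step, and only compound 1 stands apart from the other two. The only thing known to separate compound 1 from compound 3 is their drawn configuration: the fact that compounds 1 and 3 differ only in the configuration as drawn.

The compounds shown leave open what each of the other ring stereocentres does when inverted on its own, and why a change at three of them leaves the read-out within the scatter. They also leave open whether the same dependence on configuration would hold if a hydroxymethyl group or a methyl ester replaced the carboxylic acid, or if a longer chain were carried on the ring amine.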